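The source may report more compounds than this note shows. Statements on the series, on what has been measured and on what is new or still open speak of the compounds shown alone.

Measured so far:
Compound 1, `S=c1cc(-c2ccccc2)oc2ccccc12` — "not active" (no number reported)
Compound 2, `COc1ccc(-c2cc(=S)c3ccc(C)cc3o2)cc1` — "not active" (no number reported)
Compound 3, `COc1ccc(-c2cc(=S)c3ccccc3o2)cc1` — 40%

Three compounds of the shared core have been examined in an in vitro assay on BTI-TN-5B1-4 cells for inhibition of Amine oxidase [flavin-containing] A (Homo sapiens), tested at 100 uM; a higher number here means more inhibition at the concentration tested (going by the name of the read-out), a lower number less inhibition. Compound 1 is reported as "not active" (no number reported) and compound 2 as "not active" (no number reported), in both cases without a number. For the measured compounds named here, compound 3 is the only compound of the series with a number in this assay, 40%, so it is the one fixed point for judging the next step. Going by the values given here, no step between two measured compounds is available, since no pair differs in one place only.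

Compound 4, `Fc1ccc(-c2cc(=S)c3ccccc3o2)cc1`, is the next entry and is still to be measured in this assay. It differs from compound 3 as follows: fluoro in place of methoxy on an aromatic carbon.

What can be said rests on the three values alone. Compound 1, which carries no group on the phenyl ring, is reported without a number, while compound 3 with the methoxy group reaches 40%. The fluoro group of compound 4 is a smaller group than the methoxy it replaces, so a step downward from compound 3 is expected, a number 20 percentage points lower from compound 3 to compound 4 (beyond the scatter), of a size that may or may not exceed the scatter.

Compound 4 is therefore estimated at 20%, with a range from 0% to 45%, and there is a fair chance that, like compound 1 and compound 2, it is reported without a number.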

Compound 4, a percentage reported as inhibition, at one concentration (the size of the read-out at that concentration, not a potency): "not active" (no number reported)
Nothing numeric was reported for compound 4; no gap can be computed for the estimate.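

In this assay, for the compounds shown here, compound 4 gives "not active" (no number reported), so no step from compound 3 to compound 4 can be read. Nothing shown bears on this result. The compounds shown leave open how strongly the group in this place affects inhibition, with compound 3 the only compound carrying a number.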